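The source may report more compounds than this note shows. Statements on the series, on what has been measured and on what is new or still open speak of the compounds shown alone.

Compound 1 `COC1=C(C)C(=O)/C(=C(O)/C=C/c2ccc(Br)cc2)C(=O)C1(C)C` is the reference point of this account. Among the measured compounds shown here, in a functional assay on HUVEC cells (Homo sapiens) for cytotoxicity (a higher number here means that more compound is needed for the effect, a lower number that less compound is needed), compound 1 gives 3.6 ug/mL, the highest of the three numbers measured so far. Its nearest neighbour is compound 2 `COC1=C(C)C(=O)/C(=C(O)/C=C/c2ccc(OC)cc2)C(=O)C1(C)C`, which in this assay gives 2.5 ug/mL; the step of a 1.4-fold lower number from compound 1 to compound 2 (0.16 log units; within the scatter) comes with methoxy in place of bromo on an aromatic carbon. The furthest is compound 3 `COC1=C(C)C(=O)/C(=C(O)/C=C/c2ccccc2OC)C(=O)C1(C)C`, which in this assay gives 1.7 ug/mL; the step of a 2.1-fold lower number from compound 1 to compound 3 (0.33 log units; beyond the scatter) comes with 2-methoxyphenyl in place of 4-bromophenyl on a double-bonded chain carbon bound to a double-bonded chain carbon. Between the two methoxy compounds the step of a 1.5-fold lower number from compound 2 to compound 3 (0.17 log units; within the scatter) is small.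

Compound 4 `COC1=C(C)C(=O)/C(=C(O)/C=C/c2cc(C)cc(C)c2)C(=O)C1(C)C` has not been measured in this assay. It differs from compound 1 as follows: 3,5-dimethylphenyl in place of 4-bromophenyl on a double-bonded chain carbon bound to a double-bonded chain carbon. The two steps that start from compound 1, a 1.4-fold lower number from compound 1 to compound 2 (0.16 log units; within the scatter) and a 2.1-fold lower number from compound 1 to compound 3 (0.33 log units; beyond the scatter), both replaced the 4-bromophenyl, and both gave lower numbers of small to modest size. For the measured compounds named here, no measured step introduces a 3,5-dimethylphenyl, so the direction rests only on that pattern. The expected step is a 1.4-fold lower number from compound 1 to compound 4 (0.14 log units; within the scatter), lower but near the scatter. Compound 4 is therefore estimated to give 2.6 ug/mL in this assay, within a range from 1.2 ug/mL to 5.5 ug/mL.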

Compound 4, concentration for half-maximal effect: 2.5 ug/mL
The estimate for compound 4 lay 1.0-fold (0.02 log units) above the measured number; the range from low to high includes it.
By their numbers in this assay, from the lowest: compounds 3, 2, 4 and 1 (each within the scatter of the next, the first and the last beyond it).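

In this assay, among the compounds shown here, the 3,5-dimethylphenyl is the first group at this place, on a double-bonded chain carbon bound to a double-bonded chain carbon, that is built of carbon alone, and replacing the 4-bromophenyl with it gives a step (a 1.4-fold lower number from compound 1 to compound 4 (0.16 log units; within the scatter)) that matches the one seen with the 4-methoxyphenyl (a 1.4-fold lower number from compound 1 to compound 2 (0.16 log units; within the scatter)). For the compounds shown here, the new group also stays within the scatter of both methoxy compounds (no change at the digits printed from compound 2 to compound 4 (within the scatter); a 1.5-fold higher number from compound 3 to compound 4 (0.17 log units; within the scatter)), so neither oxygen nor bromine on the aromatic ring is required for a number in this narrow band, and the only step beyond the scatter among the four compounds remains the one between the 4-bromophenyl and the 2-methoxyphenyl (a 2.1-fold lower number from compound 1 to compound 3 (0.33 log units; beyond the scatter)). Nothing available explains why these different groups give such close numbers.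

The compounds shown leave open whether this flat response would persist with an amine or a carboxylic acid on the aromatic ring. They also leave open what a pyridine ring or a longer chain would do at this place, and whether any change to the shared core would move the number further than these aromatic groups have.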